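This account rests on a few compounds, and the source may have more. Where it says the series, first, only, none or still open, it means among the compounds named here.

Measured compounds
Compound 1 `N#Cc1cc(-c2nc(C(c3ccc(F)cc3)c3ccc(F)cc3)sc2CC(=O)O)ccc1F`: 520 nM
Compound 2 `O=C(O)Cc1sc(C(c2ccccc2)c2ccccc2)nc1-c1ccccc1`: 370 nM
Compound 3 `Nc1nc(-c2ccc(Cl)cc2)c(CC(=O)O)s1`: > 100000 nM

In an in vitro functional assay on HEK285-7 cells for antagonist activity at prostaglandin D2 receptor 2 (Homo sapiens), read by BRET and beta-arrestin recruitment (a lower number here means a stronger inhibitor, a higher number a weaker inhibitor), compound 1 gives 520 nM. Compound 2, which shares the core but carries no fluorine or nitrile on any of its rings, gives 370 nM in this assay, and the two numbers lie within the usual scatter of each other, so neither can be called stronger than the other. Among the compounds with values here, compound 3 is a different case: its reading in this assay is a limit, > 100000 nM, and not a number, which is the one value that sits at the limit of > 100000 nM in this assay, at which 1 of the 3 values shown sits.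

The step of interest leads from compound 1 to compound 4 `O=C(O)Cc1sc(C(c2ccc(F)cc2)c2ccc(F)cc2)nc1-c1ccnc(F)c1`, a compound not yet measured. The change is 2-fluoropyridin-4-yl in place of 3-cyano-4-fluorophenyl on an aromatic carbon. The group that leaves carries a triple bond outside aromatic rings; the group that enters is a six-membered aromatic ring with one hetero atom. Within the data shown here, no measured pair shows this change, and the two measured numbers on this core differ only within the scatter. The expected step of a 1.2-fold higher number from compound 1 to compound 4 (0.06 log units; within the scatter) is therefore small, no larger than the scatter, with no clear direction. Compound 4 is estimated at 600 nM in this assay, with a range from 200 nM to 2000 nM.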

Compound 4, half-maximal inhibitory concentration: 4.7 nM
Beside the measured number, compound 4's estimate is 130-fold (2.11 log units) above it, outside the stated range (below it).
By their numbers in this assay, from the lowest: compound 4; then compounds 2 and 1 (each within the scatter of the next). At a limit, above all of these: compound 3.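

Within the data shown here, replacing 3-cyano-4-fluorophenyl with 2-fluoropyridin-4-yl, on the aromatic carbon next to the ring nitrogen and next to the ring atom that bears a carboxymethyl group, gives a 110-fold lower number from compound 1 to compound 4 (2.04 log units; beyond the scatter) in this assay, so what this carbon carries can matter greatly, which the earlier compounds, with no step between them, could not show. The change is a single swap with several parts: the triple bond outside aromatic rings leaves, and a six-membered aromatic ring with one hetero atom replaces one of carbon only, so the step belongs to the exchange as a whole and not to any one of these parts. Nothing measured here accounts for the size of the step.

The compounds shown leave open whether the ring nitrogen or the loss of the nitrile carries the step, a question that a pyridin-4-yl group with no fluorine and a 2-cyanopyridin-4-yl group on the same carbon would help to separate. They also leave open whether a 2-aminopyridin-4-yl group, with an amine in place of the fluorine, would hold the low number of compound 4.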